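Replacing 4-chlorophenyl with 1-methyl-1H-indol-5-yl

A few compounds are considered here, and "the series" means these few. Any claim that something is new, unique, unknown or untested is made for them only; others in the source may bear on it.

Of the compounds shown here, two have been measured so far in a functional assay on HCT-116 cells (Homo sapiens) for inhibition, read by CCK-8 assay, with a stated time of 48 h; a higher number here means a weaker inhibitor, a lower number a stronger inhibitor. Compound 1 `COc1cc(-c2ccnc3cc(-c4cn(CO)c5ccccc45)nn23)cc(OC)c1OC` gives 128 nM, and compound 2 `COc1cc(-c2ccnc3cc(-c4ccc(Cl)cc4)nn23)cc(OC)c1OC` gives 3340 nM. Compound 2 therefore holds the higher of the two numbers and is the weaker inhibitor of the pair, with a gap to compound 1 that lies beyond the scatter.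

Compound 3 `COc1cc(-c2ccnc3cc(-c4ccc5c(ccn5C)c4)nn23)cc(OC)c1OC` differs from compound 2 in one place: 1-methyl-1H-indol-5-yl in place of 4-chlorophenyl on an aromatic carbon. There, 1-methyl-1H-indol-5-yl replaces 4-chlorophenyl on an aromatic carbon of a five-membered aromatic ring with 2 nitrogen, part of a fused system of two rings.

Among the measured compounds shown here, no measured step covers this change, so any expectation remains tentative. It rests on compound 1, whose value of 128 nM shows that a number far lower than that of compound 2 is reachable among these compounds. A shift toward stronger inhibition, beyond the scatter, is therefore expected in this assay. The estimated size of this shift is a 9.5-fold lower number from compound 2 to compound 3 (0.98 log units; beyond the scatter). For compound 3 the expected value is 350 nM, with an estimated range of 80 nM to 1500 nM.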

Compound 3, half-maximal inhibitory concentration: 39 nM
Estimate against measurement, compound 3: 9.0-fold (0.95 log units) above, and the stated range ends above it.
By their numbers in this assay, from the lowest: compound 3; then compound 1; then compound 2.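

Replacing 4-chlorophenyl with 1-methyl-1H-indol-5-yl on this aromatic carbon gives, in this assay, an 86-fold lower number from compound 2 to compound 3 (1.93 log units; beyond the scatter). Among the compounds shown here, this is the first direct reading of this position, as the values of compound 1 and compound 2 alone could not be tied to a change in one place. It shows that the aromatic carbon of the five-membered aromatic ring with 2 nitrogen can carry the two-ring group of 10 heavy atoms in place of the one-ring group of 7 heavy atoms, and that compound 3 reaches 39 nM with it. Nothing measured here bears on why the step is so large.

The compounds shown do not separate the contributions of the second ring, the ring nitrogen and the methyl group to this step, since all three enter together in compound 3. Also open, as far as these compounds go, is how this assay would read with an amine, a carboxylic acid or a longer chain in place of the methyl of 1-methyl-1H-indol-5-yl, and whether a step of this size would hold on other cells.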